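The source may report more compounds than this note shows. Statements on the series, on what has been measured and on what is new or still open speak of the compounds shown alone.

Measured so far:
compound 1, `OCC(O)Cn1nc2c(Br)c(Br)c(Br)c(Br)c2n1`: 27%
compound 2, `OC(CCn1nc2c(Br)c(Br)c(Br)c(Br)c2n1)c1ccc(Br)cc1`: 0%
compound 3, `OC(CCn1nc2c(Br)c(Br)c(Br)c(Br)c2n1)c1cccc(Cl)c1`: 0%

In a functional assay on CCRF-CEM cells (Homo sapiens) for antiproliferative activity, read by MTT assay, with a stated time of 48 h, tested at 50 uM (on this read-out higher numbers stand for a weaker effect at the one concentration tested and lower numbers for a stronger effect), compound 2 gives 0% and stands level with compound 3 at the digits shown, the two together being the lowest of the three numbers; compound 1 lies higher, a gap beyond the scatter. Within the data shown here, the only single-point step in the set, no change at the digits printed from compound 2 to compound 3 (within the scatter), shows that exchanging one aryl group for another on the hydroxyl-bearing chain carbon leaves the read-out unchanged.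

Compound 4, `CC(O)CCn1nc2c(Br)c(Br)c(Br)c(Br)c2n1`, is not yet measured. It differs from compound 2 in one place: methyl in place of 4-bromophenyl on a saturated chain carbon bound to an oxygen on a saturated carbon and a saturated chain carbon

Among the measured compounds shown here, no measured step removes the aryl group altogether, so the one exchange on record does not speak directly to this change. What the numbers do show is that compound 1, which carries no aryl group on its chain, sits well above compounds 2 and 3 in this assay. Compound 4, with a methyl in that position, is therefore expected to move toward compound 1, by a step of about a number 18 percentage points higher from compound 2 to compound 4 (beyond the scatter) upward, though the size is uncertain. The estimate for compound 4 in this assay is 18%, in a range from 0% to 40%.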

Compound 4, a percentage reported as activity, at one concentration (the size of the read-out at that concentration, not a potency): 45%
Beside the measured number, compound 4's estimate is 27 percentage points below it, and the stated range ends below it.
By their numbers in this assay, from the lowest: compounds 2 and 3 (each within the scatter of the next); then compound 1; then compound 4.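

In this assay, the exchange of one aryl group for another had left the number unchanged, but this position does respond when the ring is lost: methyl in place of 4-bromophenyl gives a number 45 percentage points higher from compound 2 to compound 4 (beyond the scatter) and methyl in place of 3-chlorophenyl gives a number 45 percentage points higher from compound 3 to compound 4 (beyond the scatter) and so leaves a much weaker effect. The chain on the aromatic nitrogen also counts among compounds without an aryl group, as 2-hydroxypropyl in place of 1,2-dihydroxyethyl gives a number 18 percentage points higher from compound 1 to compound 4 (beyond the scatter) and compound 4 has the weakest effect of the four. Nothing available explains either change.

Going by these compounds, whether the aromatic ring itself is needed remains open, as a cyclohexyl group or an unsubstituted phenyl at this position would show. So does the effect of an amine or a longer chain in place of the methyl.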